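Replacing the Fluorophenyl Arm on a Shared Core

The compounds below may be only part of what the source reports. "The series", "measured", "known", "first", "only" and "open" are said of these compounds alone.

Measured compounds:
- compound 1, `Fc1ccc(-c2cn3ccnc3c(-c3ccc4ncn(C5CCCCC5)c4c3)n2)cc1`, gives 3.49% in a functional assay on KM12 cells (Homo sapiens) for inhibition, read by sulforhodamine B assay, with a stated time of 48 h, tested at 10 uM; on this read-out higher numbers stand for more inhibition at the one concentration tested (going by the name of the read-out) and lower numbers for less inhibition
- compound 2, `c1cn2cc(-c3ccsc3)nc(-c3ccc4ncn(C5CCCCC5)c4c3)c2n1`, gives 15.4%
- compound 3, `CC(=O)c1ccc(-c2cn3ccnc3c(-c3ccc4ncn(C5CCCCC5)c4c3)n2)cc1`, gives 11.7%

Within the data shown here, compound 1 stands lowest of the three, though its gap to compound 3 is within the scatter; only the step to compound 2 is beyond it. Compound 4, `FC(F)(F)c1cccc(-c2cn3ccnc3c(-c3ccc4ncn(C5CCCCC5)c4c3)n2)c1`, differs from compound 1 by 3-(trifluoromethyl)phenyl in place of 4-fluorophenyl on an aromatic carbon. Two measured steps also change the 4-fluorophenyl group of compound 1: a number 11.9 percentage points higher from compound 1 to compound 2 (beyond the scatter), and a number 8.2 percentage points higher from compound 1 to compound 3 (within the scatter). Both moved the number up, one modestly and one within the scatter, so for compound 4 a small rise in this assay, or no change beyond the scatter, is expected. The expected step is a number 4.5 percentage points higher from compound 1 to compound 4 (within the scatter). Compound 4 is therefore estimated at 8%, with a range from -3% to 20%.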

Compound 4, a percentage reported as inhibition, at one concentration (the size of the read-out at that concentration, not a potency): 1.25%
The estimate for compound 4 lay 6.8 percentage points above the measured number; the range from low to high includes it.
By their numbers in this assay, from the lowest: compounds 4, 1, 3 and 2 (each within the scatter of the next, the first and the last beyond it).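

Swapping in 3-(trifluoromethyl)phenyl brings no gain over 4-fluorophenyl in this assay, with a number 2.2 percentage points lower from compound 1 to compound 4 (within the scatter), so not every replacement at this position lifts the number as thiophen-3-yl did. The other two comparisons show that the group here can still separate compounds beyond the scatter, with a number 10.5 percentage points lower from compound 3 to compound 4 (beyond the scatter) and a number 14.2 percentage points lower from compound 2 to compound 4 (beyond the scatter). Nothing available here explains these differences.

Still open, from the compounds shown here alone, is whether an amine or a carboxylic acid on this aromatic ring would give a clearly higher number. Equally open, going by these compounds, is what a longer chain would do in place of the ring.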